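From an amide to a urea on a shared core

A few compounds are considered here, and "the series" means these few. Any claim that something is new, unique, unknown or untested is made for them only; others in the source may bear on it.

Four compounds share one core and are compared in a functional assay on UACC-257 cells (Homo sapiens) for inhibition, read by sulforhodamine B assay, with a stated time of 48 h; on this read-out higher numbers stand for weaker inhibition of growth and lower numbers for stronger inhibition of growth. Compound 1 `O=C(Nc1cccc(-n2cc(-c3ccncc3)c(-c3ccc(Cl)c(O)c3)n2)c1)Nc1cccc(C(F)(F)F)c1` gives 19100 nM. Among the compounds with values here, compound 3 `O=C(Nc1cccc(-n2cc(-c3ccncc3)c(-c3ccc(Cl)c(O)c3)n2)c1)Nc1ccc(Cl)c(Cl)c1` gives 3160 nM, and the step of a 6.0-fold lower number from compound 1 to compound 3 (0.78 log units; beyond the scatter) is the only measured change of one group in this set. Within the data shown here, compound 2 `COc1cc(-c2nn(-c3cccc(NC(=O)c4cccc(C(F)(F)F)c4)c3)cc2-c2ccncc2)ccc1Cl` gives only a limit of the assay, > 50000 nM, so its true number is not known; this is the limit described as the limit of > 50000 nM in this assay, at which 1 of the 3 values shown sits, and compound 2 is the one value in the set that sits there. Compound 4 `COc1cc(-c2nn(-c3cccc(NC(=O)Nc4cccc(C(F)(F)F)c4)c3)cc2-c2ccncc2)ccc1Cl` differs from compound 2 by (3-(trifluoromethyl)phenyl)amino in place of 3-(trifluoromethyl)phenyl on a carbonyl carbon, turning the amide into a urea. Among the measured compounds shown here, no measured step covers this change: the step from compound 1 to compound 3 alters the outer ring, not the link. Compound 1 carries the same urea and outer ring as compound 4, which suggests a weak inhibitor again. Compound 4 is therefore expected to give about 25000 nM in this assay, somewhere between 8000 nM and 60000 nM, an estimated step of an at least 2.0-fold lower number from compound 2 to compound 4 (0.30 log units; that floor lies within the scatter) that may well end at the limit again.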

Compound 4, concentration for total growth inhibition: 2310 nM
For compound 4 the middle estimate is 11-fold (1.03 log units) above the measured one, outside the stated range (below it).
By their numbers in this assay, from the lowest: compounds 4 and 3 (each within the scatter of the next); then compound 1. At a limit, above all of these: compound 2.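

Compound 2 stands at a limit of the assay, not at a number: the limit of > 50000 nM in this assay, at which 1 of the 4 values shown sits. In this assay, (3-(trifluoromethyl)phenyl)amino in place of 3-(trifluoromethyl)phenyl on a carbonyl carbon turns the amide into a urea and gives an at least 21-fold lower number from compound 2 to compound 4 (1.33 log units; beyond the scatter), so at this position the link itself makes a large difference to the read-out. Within the ureas, methyl in place of hydrogen on an oxygen on an aromatic ring gives an 8.3-fold lower number from compound 1 to compound 4 (0.92 log units; beyond the scatter), which shows that this second place also counts, a point the earlier compounds could not show.

Still open, on these data alone, is whether the urea gives a similar step when that oxygen carries hydrogen, and whether the 3,4-dichlorophenyl step holds when it carries methyl. Also open, as far as these compounds go, is how an ethyl group on that oxygen, or a thiourea in place of the urea, would read in this assay.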